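Replacing chloro with methoxy in compound 2

The source may hold more compounds than are shown below. What is called first, only, known or untested is meant among the compounds shown, and "the series" means these compounds.

In a functional assay on MCF7 cells (Homo sapiens) for cytotoxicity, read by MTT assay, with a stated time of 72 h (on this read-out higher numbers stand for weaker inhibition and lower numbers for stronger inhibition), two compounds have been measured so far. Compound 1 `COc1cccc(/C=C2\CCC/C(=C\c3ccc(Br)cc3)C2=O)c1OC` gives 13800 nM, and compound 2 `COc1ccc(/C=C2\CCC/C(=C\c3ccc(Cl)cc3)C2=O)cc1OC` gives 6300 nM. Compound 2 therefore holds the lower of the two numbers, and its gap to compound 1 lies beyond the scatter, which makes it the stronger inhibitor of this pair. Compound 3 `COc1ccc(/C=C2\CCC/C(=C\c3ccc(OC)c(OC)c3)C2=O)cc1` has not yet been measured. It differs from compound 2 in one place, with methoxy in place of chloro on an aromatic carbon, para to a large group (methoxy in place of chloro on an aromatic carbon). The two measured compounds differ from each other in more than one place, so they offer no direct guide to this change. The expected move, a 1.3-fold higher number from compound 2 to compound 3 (0.10 log units; within the scatter), is small, leans towards weaker inhibition and is estimated to stay within the scatter. For compound 3 the expected value in this assay is 8000 nM, with an estimated range from 3000 nM to 20000 nM.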

Compound 3, half-maximal inhibitory concentration: 7800 nM
Compound 3: the middle estimate sits 1.0-fold (0.01 log units) above what was measured; measured number inside the range.
By their numbers in this assay, from the lowest: compounds 2, 3 and 1 (each within the scatter of the next, the first and the last beyond it).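

In this assay, going by these compounds alone, the change from 4-chlorophenyl to 4-methoxyphenyl gives a 1.2-fold higher number from compound 2 to compound 3 (0.09 log units; within the scatter), the first direct reading at this place, on an aromatic carbon para to a large group. Chloro and methoxy therefore cannot be told apart here, so this one swap, which brings in one more heavy atom and a hydrogen-bond acceptor, leaves the cytotoxicity reading in the same range. Nothing available explains why the two groups read alike.

Within the data shown here, whether the same place would accept an amine, a carboxylic acid or a longer alkoxy chain remains open, since chloro and methoxy are the only two groups compared there. Compound 1 differs from the other two compounds in more than one place, so its value cannot be assigned to any single change.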